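Working notes: from compound 3 to compound 4

The source may report more compounds than this note shows. Statements on the series, on what has been measured and on what is new or still open speak of the compounds shown alone.

In a functional assay on PC-3 cells (Homo sapiens) for antiproliferative activity, read by sulforhodamine B assay (on this read-out lower numbers stand for stronger inhibition of growth and higher numbers for weaker inhibition of growth), compound 1 (`CC(C)(C)CCOc1cccc(O)c1C(=O)/C=C/c1ccc(C(=O)O)cc1`) gives 6500 nM as its value and compound 2 (`CC(C)(C)CCOc1cccc(O)c1C(=O)/C=C/c1ccc(O)cc1`) gives 3220 nM as its value. That gap, a 2.0-fold lower number from compound 1 to compound 2 (0.31 log units; beyond the scatter) as a step, lies at a place not involved in the next change, so it carries little weight here.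

Compound 3 (`CC(C)=CCOc1cccc(O)c1C(=O)/C=C/c1ccc(O)cc1`) gives > 30000 nM and this is a limit of the assay, not a number. On the numbers shown, it sits at the limit of > 30000 nM in this assay, at which 1 of the 3 values shown sits, and nothing finer can be said.

Compound 4 (`CCCCOc1cccc(O)c1C(=O)/C=C/c1ccc(O)cc1`) alters one group of compound 3 (propyl in place of 2-methylprop-1-en-1-yl on a saturated chain carbon bound to an oxygen on an aromatic ring): propyl in place of 2-methylprop-1-en-1-yl on a saturated chain carbon bound to an oxygen on an aromatic ring, which also reads 3-methylbut-2-en-1-yl to butyl. The step that bears on this is an at least 9.3-fold higher number from compound 2 to compound 3 (0.96 log units; beyond the scatter) at the same place, with neopentyl leaving and 2-methylprop-1-en-1-yl entering. Compound 4 has no double bond in this chain, as in compound 2, but carries propyl where compound 2 carries neopentyl. With compound 2 at 3220 nM as the nearest measured value, a partial return towards it is expected. A repeat of the limit seen for compound 3 stays possible. The expected step is an at least 2.5-fold lower number from compound 3 to compound 4 (0.39 log units; beyond the scatter) in the direction of a lower number. The estimate for compound 4 is 12000 nM with 4000 nM to 30000 nM as the expected range.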

Compound 4, concentration for 50% growth inhibition: > 30000 nM
Compound 4: only a limit was reported; the forecaster's own chance of this, stated with the estimate: 30%; middle value at least 2.5-fold (0.39 log units) away from the limit.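

Saturating the chain does not by itself bring back growth inhibition: in this assay compound 4, which has butyl and no double bond in this chain, gives > 30000 nM, and this is a limit of the assay, not a number. The loss of the tert-butyl end of the chain is enough to lose the measurable activity of compound 2, with ethyl in place of tert-butyl on a saturated chain carbon, two bonds along the chain from an oxygen on an aromatic ring giving an at least 9.3-fold higher number from compound 2 to compound 4 (0.96 log units; beyond the scatter). Among compound 2, compound 3 and compound 4, only the chain ending in tert-butyl gives a measured value, while 3-methylbut-2-en-1-yl and butyl share the same ceiling: the limit of > 30000 nM in this assay, at which 2 of the 4 values shown sit.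

Going by these compounds, the step between compound 3 and compound 4 cannot be read, so any difference between the 3-methylbut-2-en-1-yl and butyl chains stays open. Also open, on these data alone, is how a chain ending in isopropyl, a longer chain such as hexyl, or a chain ending in an amine would read at this place.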